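Benzophenone variation on the shared dimethylchromene pyridone core

This account rests on a few compounds, and the source may have more. Where it says the series, first, only, none or still open, it means among the compounds named here.

Of the compounds shown here, three on a common core have been measured in a functional assay (trachea) with Rattus norvegicus as the target; a lower number here means a less potent compound, a higher number a more potent compound, by a factor of ten per unit of this negative logarithm. Compound 1 `CC1(C)C=C(n2ccccc2=O)c2cc(C(=O)c3ccc([N+](=O)[O-])cc3)ccc2O1` carries a 4-nitrophenyl on the carbonyl carbon and gives 6.09. Compound 2 `CC1(C)C=C(n2ccccc2=O)c2cc(C(=O)c3ccccc3[N+](=O)[O-])ccc2O1`, with 2-nitrophenyl, gives 5.64. Within the data shown here, compound 3 `Cc1ccccc1C(=O)c1ccc2c(c1)C(n1ccccc1=O)=CC(C)(C)O2`, with 2-methylphenyl, gives 6.25, the highest of the three numbers, though its gap to compound 1 lies within the scatter; only the step of a number 0.61 log units higher from compound 2 to compound 3 (beyond the scatter) is beyond it. The other step with a clear size is a number 0.45 log units lower from compound 1 to compound 2 (beyond the scatter).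

Compound 4 `CC1(C)C=C(n2ccccc2=O)c2cc(C(=O)c3c(F)cccc3F)ccc2O1` is not yet measured. Change: 2,6-difluorophenyl in place of 2-methylphenyl on a carbonyl carbon. Among the measured compounds shown here, no measured pair swaps a methyl for fluorine, so the bearing of the measured steps is indirect. The step from compound 2 to compound 3 shows that the group on this phenyl can move the number by a modest amount, and the step from compound 1 to compound 2 shows the same for where a nitro sits. For the measured compounds named here, with two fluorines entering and no close precedent, a modest step in either direction is plausible and a drop is judged somewhat more likely than a rise. Compound 4 is therefore expected near compound 3 or a little lower, at 6, ranging from 5.5 to 6.5, an estimated step of a number 0.25 log units lower from compound 3 to compound 4 (within the scatter).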

Compound 4, logarithm of the reciprocal of the active concentration, log(1/C): 5.99
Beside the measured number, compound 4's estimate is 0.01 log units above it; the range from low to high includes it.
By their numbers in this assay, from the lowest: compound 2; then compounds 4, 1 and 3 (each within the scatter of the next).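

With a number 0.26 log units lower from compound 3 to compound 4 (within the scatter) and a number 0.10 log units lower from compound 1 to compound 4 (within the scatter), the 2,6-difluorophenyl group joins 2-methylphenyl and 4-nitrophenyl in a single band at this position in this assay, so these three groups on the carbonyl carbon cannot be told apart. Among these compounds, only a number 0.35 log units higher from compound 2 to compound 4 (beyond the scatter) clears the scatter, which gives compound 2 and its 2-nitrophenyl a third step beyond the scatter and leaves it as the one compound set apart from the others. The band now holds fluorine, methyl and nitro substituents, so among these compounds the kind of group on this phenyl does not by itself fix the number, with compound 2 as the exception.

Nothing available here bears on why compound 2 stands apart or on what underlies any of these steps. Also open, from the compounds shown here alone, is whether an amine or a carboxylic acid on this phenyl, or a cyclohexyl ring in its place, would stay in the band with compound 1, compound 3 and compound 4 or fall toward compound 2.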